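A few compounds are considered here, and "the series" means these few. Any claim that something is new, unique, unknown or untested is made for them only; others in the source may bear on it.

Measured in an ADME assay on microsomes from liver (Homo sapiens) for pharmacokinetics, read by LC-MS, with a stated time of 60 min, tested at 1 uM (a lower number here means slower removal, a higher number faster removal of the compound), so far:
compound 1 `O=C(NCc1ccc(S(=O)(=O)c2cncc(C(F)(F)F)c2)cc1)N1Cc2ccncc2C1`: 13 mL/min/kg
compound 2 `CCCn1cc(S(=O)(=O)c2ccc(CNC(=O)N3Cc4ccncc4C3)cc2)cn1`: 11 mL/min/kg
compound 3 `O=C(NCc1ccc(S(=O)(=O)C2CCOCC2)cc1)N1Cc2ccncc2C1`: 6 mL/min/kg

Compound 3 carries the lowest of the three numbers. Its distance from compound 1, a 2.2-fold lower number from compound 1 to compound 3 (0.34 log units; beyond the scatter), is beyond the scatter, while a 1.8-fold lower number from compound 2 to compound 3 (0.26 log units; within the scatter) and a 1.2-fold lower number from compound 1 to compound 2 (0.07 log units; within the scatter) are within it, so only the gap to compound 1 counts as a real difference; compounds 2 and 3 cannot be ordered.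

Compound 4 `O=C(NCc1ccc(S(=O)(=O)N2CC3(CCOCC3)C2)cc1)N1Cc2ccncc2C1` has not been measured. It differs from compound 3 in one place: a group of 9 heavy atoms (7 carbon, 1 nitrogen, 1 oxygen; one four-membered non-aromatic ring with 1 hetero atom, one six-membered non-aromatic ring with 1 hetero atom) in place of a group of 6 heavy atoms (5 carbon, 1 oxygen; one six-membered non-aromatic ring with 1 hetero atom), on a sulfonyl sulfur.

Among the compounds with values here, all three measured steps swap the group on the sulfonyl sulfur, and the largest of them, a 2.2-fold lower number from compound 1 to compound 3 (0.34 log units; beyond the scatter), is only modest; the whole series so far spans a narrow band in this assay. Within the data shown here, none of the measured steps puts a nitrogen on the sulfonyl sulfur or adds a second ring at that position, so the change to compound 4 has no direct precedent here. Given the narrow spread, no step beyond the scatter is expected, in either direction.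

Compound 4 is expected to give 7 mL/min/kg, with a range of 3.5 mL/min/kg to 14 mL/min/kg. The step of a 1.2-fold higher number from compound 3 to compound 4 (0.07 log units; within the scatter) implied by this estimate is expected to sit within the scatter.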

Compound 4, clearance: 13 mL/min/kg
For compound 4 the middle estimate is 1.9-fold (0.27 log units) below the measured one; measured number inside the range.
By their numbers in this assay, from the lowest: compounds 3, 2, 1 and 4 (each within the scatter of the next, the first and the last beyond it).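

In this assay, the group with one four-membered and one six-membered non-aromatic ring, joined to the sulfonyl sulfur through its nitrogen, does not keep the number seen with oxan-4-yl: a 2.2-fold higher number from compound 3 to compound 4 (0.34 log units; beyond the scatter), a modest step but one beyond the scatter. Against the two aromatic groups the new group cannot be told apart, with a 1.2-fold higher number from compound 2 to compound 4 (0.07 log units; within the scatter) and no change at the digits printed from compound 1 to compound 4 (within the scatter), both within the scatter. A non-aromatic ring on the sulfonyl sulfur is therefore not enough to set a compound apart from compound 1, since oxan-4-yl in compound 3 does so and the group in compound 4 does not.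

Still open, as far as these compounds go, is whether the step from oxan-4-yl follows from the nitrogen on the sulfonyl sulfur or from the added ring, a question that a dimethylamino group or a morpholin-4-yl group at this place would help to separate. Nothing available here gives a measured reason for the step.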